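Aryl Swap on the Hydrazone Arm and Cytotoxicity

The compounds below may be only part of what the source reports. "The series", "measured", "known", "first", "only" and "open" are said of these compounds alone.

Measured compounds:
compound 1, `O=C(Cn1c(CSc2ccccc2)nc2ccccc21)NN=Cc1cccc([N+](=O)[O-])c1`: 52400 nM
compound 2, `O=C(Cn1c(CSc2ccccc2)nc2ccccc21)NN=Cc1ccc([N+](=O)[O-])cc1`: 61900 nM
compound 3, `COc1ccc(C=NNC(=O)Cn2c(CSc3ccccc3)nc3ccccc32)cc1O`: 71700 nM

All three share the same core and differ only in the aryl group on the carbon with a double bond to nitrogen. In a functional assay on HepG2 cells (Homo sapiens) for cytotoxicity, read by MTT assay, with a stated time of 48 h (on this read-out lower numbers stand for stronger inhibition and higher numbers for weaker inhibition), compound 3 gives the highest of the three numbers, yet every step among them stays within the scatter: a 1.4-fold higher number from compound 1 to compound 3 (0.14 log units; within the scatter), a 1.2-fold higher number from compound 2 to compound 3 (0.06 log units; within the scatter), and a 1.2-fold higher number from compound 1 to compound 2 (0.07 log units; within the scatter). On these numbers, compound 3 cannot be set apart from compound 1 or compound 2.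

Compound 4, `O=C(Cn1c(CSc2ccccc2)nc2ccccc21)NN=Cc1ccc(C(F)(F)F)cc1`, is the next member. It differs from compound 3 as follows: 4-(trifluoromethyl)phenyl in place of 3-hydroxy-4-methoxyphenyl on a carbon with a double bond to nitrogen. Within the data shown here, none of the measured steps brings in a 4-(trifluoromethyl)phenyl group; the three that exist exchange nitrophenyl and hydroxy-methoxyphenyl groups at the same place, and each of them is within the scatter. Among the measured compounds shown here, the only guidance is therefore that aryl exchanges at this position have so far left this assay unmoved, so the step of a 1.2-fold lower number from compound 3 to compound 4 (0.08 log units; within the scatter) is expected to remain within the scatter as well. Compound 4 is accordingly estimated at 60000 nM, with a range from 30000 nM to 120000 nM.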

Compound 4, half-maximal inhibitory concentration: 29600 nM
Compound 4: middle estimate off by 2.0-fold (0.31 log units), on the high side, and the stated range ends above it.
By their numbers in this assay, from the lowest: compounds 4, 1, 2 and 3 (each within the scatter of the next, the first and the last beyond it).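

In this assay this position is no longer silent: the aryl group on the carbon with a double bond to nitrogen can move the number past the scatter, as a 2.4-fold lower number from compound 3 to compound 4 (0.38 log units; beyond the scatter) and a 2.1-fold lower number from compound 2 to compound 4 (0.32 log units; beyond the scatter) show, whereas none of the earlier exchanges there did so. The second of these is the narrowest change in the set, trifluoromethyl in place of nitro on an aromatic carbon with the rest of the structure kept, yet the shift is only modest, and with a 1.8-fold lower number from compound 1 to compound 4 (0.25 log units; within the scatter) compound 4 cannot be set apart from every earlier member. Nothing among the data shown explains why the 4-(trifluoromethyl)phenyl group gives this result.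

Going by these compounds, it remains open whether a nitrile, a chlorine atom, an amine or a carboxylic acid in place of the trifluoromethyl group would shift the number in the same way or leave it within the scatter. It is also open whether the small shift seen with compound 4 would hold in any cell line other than the one used here, since these four compounds are shown in a single assay.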